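Swapping a Tetrazole Tail for a Cyclopentyl Acetic Acid

A few compounds are considered here, and "the series" means these few. Any claim that something is new, unique, unknown or untested is made for them only; others in the source may bear on it.

Of the compounds shown here, three that share one core have been measured so far in an assay on membranes from lung (Cavia porcellus) for binding affinity to cysteinyl leukotriene receptor (Homo sapiens); on this read-out higher numbers stand for weaker inhibition and lower numbers for stronger inhibition. Compound 1 `O=C(O)CC1CCCC1Cc1ccc(OCc2ccc3ccccc3n2)cc1` gives 100 nM in this assay. Compound 2 `c1ccc2nc(COc3ccc(OCCCc4nnn[nH]4)cc3)ccc2c1` gives 69 nM in this assay. Compound 3 `O=C(O)CCCCc1cccc(OCc2ccc3ccccc3n2)c1` gives 100 nM in this assay. Within the data shown here, compound 2 shows the lowest of the three numbers, but its gaps to compound 1 and to compound 3 both lie within the scatter of repeated measurements, so the three numbers cannot be told apart with confidence, and no single compound can be called the strongest.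

Compound 4 `O=C(O)CC1CCC(c2ccc(OCc3ccc4ccccc4n3)cc2)C1` has not yet been measured. It differs from compound 2 in one place: 3-(carboxymethyl)cyclopentyl in place of 3-(1H-tetrazol-5-yl)propoxy on an aromatic carbon. The change therefore exchanges one acidic group, the tetrazole on a three-carbon chain through an oxygen, for another, a carboxylic acid on a carbon ring, at the position para to a large group. A closely related pattern, a carboxymethyl on a cyclopentyl ring, already appears in compound 1, whose value sits within the scatter of compound 2.

Because compound 1 gives 100 nM and compound 2 gives 69 nM, the step from compound 2 to compound 4 is expected to stay within the scatter, with a 1.4-fold higher number from compound 2 to compound 4 (0.16 log units; within the scatter) as the estimated change. Compound 4 is accordingly estimated at 100 nM in this assay, with a plausible range from 35 nM to 300 nM.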

Compound 4, inhibition constant: 22 nM
The estimate for compound 4 lay 4.5-fold (0.66 log units) above the measured number; measured number below the stated range.
By their numbers in this assay, from the lowest: compound 4; then compounds 2, 1 and 3 (each within the scatter of the next).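

Among these compounds, this is the first difference that rises above the scatter: in this assay the step is a 3.1-fold lower number from compound 2 to compound 4 (0.50 log units; beyond the scatter), whereas the three earlier numbers could not be told apart. It shows that this position, an aromatic carbon para to a large group, does respond to the group placed on it, and that a lower number, meaning stronger inhibition, can be reached there with 3-(carboxymethyl)cyclopentyl in place of 3-(1H-tetrazol-5-yl)propoxy. The swap alters several things at once, including the ring type and the acidic end of the group, and nothing available here explains the gain or assigns it to any one of these features.

The two compounds alone leave open whether the carboxylic acid or the carbon ring carries the gain, and a tetrazole placed directly on the cyclopentyl ring would separate the two. Going by these compounds, it also remains open how a cyclohexyl ring in place of the cyclopentyl ring, or a primary amide in place of the carboxylic acid, would read at this position.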